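Benzyl in place of benzoyl on the oxygen: expected outcome

The compounds below may be only part of what the source reports. "The series", "measured", "known", "first", "only" and "open" are said of these compounds alone.

Measured so far:
compound 1 `O=C(OCC(O)Cn1cc(CN2CCN(c3ccccc3)CC2)nn1)c1ccccc1` — 11%
compound 2 `CCOC(=O)C1CCCN(Cc2cn(C3CCCCC3OC(=O)COc3ccccc3)nn2)C1` — 21%

In an assay on nucleic acid for inhibition of Nucleic Acid, read by fluorescence, tested at 100 uM (on this read-out higher numbers stand for more inhibition at the one concentration tested (going by the name of the read-out) and lower numbers for less inhibition), compound 1 gives 11%, while compound 2 gives 21%; the two numbers lie within the usual scatter of each other and do not separate. Compound 3 `OC(COCc1ccccc1)Cn1cc(CN2CCN(c3ccccc3)CC2)nn1` remains to be measured. It differs from compound 1 by benzyl in place of benzoyl on an oxygen on a saturated carbon. Among the measured compounds shown here, no measured pair shows the effect of this change, so the expected step is none beyond the scatter. Compound 3 is therefore estimated at 12%, in the range 0% to 28%, which means an expected step of a number 1 percentage points higher from compound 1 to compound 3 (within the scatter).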

Compound 3, a percentage reported as inhibition, at one concentration (the size of the read-out at that concentration, not a potency): 37%
Compound 3: middle estimate off by 25 percentage points, on the low side, and the stated range ends below it.
By their numbers in this assay, from the lowest: compounds 1 and 2 (each within the scatter of the next); then compound 3.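

In this assay, among the compounds shown here, benzyl in place of benzoyl on an oxygen on a saturated carbon gives the first readable step at this position (a number 26 percentage points higher from compound 1 to compound 3 (beyond the scatter)). The position therefore responds to this change, and in this one pair, inhibition at the single concentration tested does not depend on keeping the benzoyl carbonyl. No measurement at hand accounts for the step.
Open, from the compounds shown here alone, is whether a phenethyl group, a longer chain or a plain methyl on this oxygen keeps the gain. Also open, going by these compounds, is whether the same change carries over to the core of compound 2.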